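The source may hold more compounds than are shown below. What is called first, only, known or untested is meant among the compounds shown, and "the series" means these compounds.

Of the compounds shown here, two of a shared core have been measured. Compound 1 `O=C1/C(=C/c2cccnc2)CN(S(=O)(=O)c2ccc(C(F)(F)F)cc2)C/C1=C\c1ccccc1C(F)(F)F` and compound 2 `N#Cc1ccc(S(=O)(=O)N2C/C(=C\c3cccnc3)C(=O)/C(=C/c3ccccc3C(F)(F)F)C2)cc1` differ by cyano in place of trifluoromethyl on an aromatic carbon. In a functional assay on SMMC-7721 cells (Homo sapiens) for cytotoxicity, read by MTT assay, with a stated time of 24 h (a higher number here means a weaker inhibitor, a lower number a stronger inhibitor), compound 1 gives 1730 nM, and compound 2 gives 9650 nM. Among the compounds with values here, the single measured step, a 5.6-fold higher number from compound 1 to compound 2 (0.75 log units; beyond the scatter), is the whole of what is known so far. On these numbers compound 2 stands at the higher of the two values, with compound 1 as its nearest neighbour at the lower one.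

Compound 3 `N#Cc1ccc(S(=O)(=O)N2C/C(=C\c3ccncc3)C(=O)/C(=C/c3ccccc3C(F)(F)F)C2)cc1` has not yet been measured. It differs from compound 2 by pyridin-4-yl in place of pyridin-3-yl on a double-bonded chain carbon bound to a double-bonded ring carbon. Within the data shown here, no measured step bears on this change: the only step available concerns a different group, cyano in place of trifluoromethyl on an aromatic carbon, and says nothing about the pyridyl group. With nothing to go on, no step beyond the scatter is expected in this assay in either direction. The step from compound 2 to compound 3 is therefore estimated as no change at the digits printed from compound 2 to compound 3 (within the scatter). Compound 3 is expected to give 9650 nM, with a range from 3200 nM to 29000 nM.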

Compound 3, half-maximal inhibitory concentration: 9610 nM
Compound 3: the middle estimate sits 1.0-fold (0.00 log units) above what was measured; low and high end bracket the measured number.
By their numbers in this assay, from the lowest: compound 1; then compounds 3 and 2 (each within the scatter of the next).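

In this assay, the pyridyl group on a double-bonded chain carbon bound to a double-bonded ring carbon now has a measured step of its own: pyridin-4-yl in place of pyridin-3-yl gives a result within the scatter (a 1.0-fold lower number from compound 2 to compound 3 (0.00 log units; within the scatter)). The assay therefore does not separate these two pyridyl groups when cyano is present on the other aromatic ring, whereas cyano in place of trifluoromethyl gave a step beyond the scatter (a 5.6-fold higher number from compound 1 to compound 2 (0.75 log units; beyond the scatter)). No measurement shown here offers an explanation for this absence of separation.

The compounds shown leave open whether pyridin-3-yl and pyridin-4-yl would also remain within the scatter of each other with trifluoromethyl in place of cyano, since this comparison rests on the single cyano pair. They also leave open whether a larger step would appear with pyridin-2-yl, a plain phenyl ring or a phenyl ring carrying an amine or a carboxylic acid on the same double-bonded chain carbon.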